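Swapping the ring methyl for a cyclopropylsulfonyl group

A few compounds are considered here, and "the series" means these few. Any claim that something is new, unique, unknown or untested is made for them only; others in the source may bear on it.

Of the compounds shown here, three sharing one core have been measured in an assay for inhibition of mitogen-activated protein kinase kinase kinase 14 (Homo sapiens), read by luminescence and ADP-Glo, with a stated time of 120 min, in the presence of a further agent that is not named here; a higher number here means a weaker inhibitor, a lower number a stronger inhibitor. Compound 1 `C[C@@H]1CN(c2ccc(C#CC(C)(O)c3nccs3)cc2Nc2ncnc3[nH]ccc23)CCN1` gives 210 nM, compound 2 `C[C@H]1CN(c2ccc(C#CC(C)(O)c3nccs3)cc2Nc2ncnc3[nH]ccc23)CCN1` gives 69.2 nM, and compound 3 `CN1CCN(c2ccc(C#CC(C)(O)c3nccs3)cc2Nc2ncnc3[nH]ccc23)CC1` gives 78.3 nM. Compound 3 thus sits second highest of the three numbers: the step of a 1.1-fold higher number from compound 2 to compound 3 (0.05 log units; within the scatter) is within the scatter, while the step of a 2.7-fold lower number from compound 1 to compound 3 (0.43 log units; beyond the scatter) is beyond the scatter. The step of a 3.0-fold lower number from compound 1 to compound 2 (0.48 log units; beyond the scatter) is modest, and the fact that one of compounds 1 and 2 is drawn with a defined configuration and the other without, at the place where they differ is the only fact that accompanies it.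

Compound 4 `CC(O)(C#Cc1ccc(N2CCN(S(=O)(=O)C3CC3)CC2)c(Nc2ncnc3[nH]ccc23)c1)c1nccs1` differs from compound 3 by cyclopropylsulfonyl in place of methyl on an amine nitrogen in a ring. For the measured compounds named here, none of the measured steps exchanges a methyl for a cyclopropylsulfonyl group; the two measured steps, a 3.0-fold lower number from compound 1 to compound 2 (0.48 log units; beyond the scatter) and a 2.7-fold lower number from compound 1 to compound 3 (0.43 log units; beyond the scatter), both concern a methyl on the six-membered ring and were modest. The expected step in this assay from compound 3 to compound 4 is therefore a 1.1-fold higher number from compound 3 to compound 4 (0.06 log units; within the scatter), with no direction supported beyond the scatter. Compound 4 is estimated at 90 nM, in the range 25 nM to 350 nM.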

Compound 4, half-maximal inhibitory concentration: 16.2 nM
Estimate against measurement, compound 4: 5.6-fold (0.74 log units) above; the measured number lies below the stated range.
By their numbers in this assay, from the lowest: compound 4; then compounds 2 and 3 (each within the scatter of the next); then compound 1.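

In this assay the amine nitrogen in the ring proves able to carry a much larger group than methyl, and cyclopropylsulfonyl gives the stronger inhibitor, with a 4.8-fold lower number from compound 3 to compound 4 (0.68 log units; beyond the scatter) as the step at this position. The earlier compounds shown here moved only a methyl around this ring, whereas compound 4 now stands clear of both methyl isomers, with a 4.3-fold lower number from compound 2 to compound 4 (0.63 log units; beyond the scatter) as a modest step and a 13-fold lower number from compound 1 to compound 4 (1.11 log units; beyond the scatter) as a large one. The one fact on record concerns the configuration in compounds 1 and 2 and offers no explanation for this gain.

The compounds shown leave open whether the gain follows the sulfonyl or the cyclopropyl part of the new group. A methylsulfonyl or a cyclopropylcarbonyl group on the same nitrogen would separate the two.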